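Replacing the 3-(methylsulfanyl)propyl group of compound 2

This account rests on a few compounds, and the source may have more. Where it says the series, first, only, none or still open, it means among the compounds named here.

In an ADME assay on BHK cells (Mesocricetus auratus) for cytotoxicity, read by MTT assay, with a stated time of 96 h (on this read-out higher numbers stand for lower toxicity in this test and lower numbers for higher toxicity in this test), compound 1 (`CCNC(=S)Nc1cccc(C(F)(F)F)c1`) gives > 100000 nM, which is a limit of the assay. Compound 2 (`CSCCCNC(=S)Nc1cccc(C(F)(F)F)c1`) gives > 100000 nM, which is also a limit, so it has no exact number in this assay. Compound 3 (`Fc1cccc(NC(=S)Nc2cccc(C(F)(F)F)c2)c1`) carries 3-fluorophenyl in place of 3-(methylsulfanyl)propyl on an amide-type nitrogen.

Among the measured compounds shown here, only one measured step is available, a step that the two limits leave unreadable from compound 1 to compound 2, and it gives no size to carry forward. The evidence amounts to the limit of > 100000 nM in this assay, at which 2 of the 2 values shown sit. Neither compound 1 nor compound 2 has a ring in this place, so the measurements do not test the new group directly.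

With compound 2 at > 100000 nM, a limit, any readable change can only run toward lower numbers. A moderate move in that direction is therefore expected, although compound 3 may also stay at the limit. The expected change is an at least 2.0-fold lower number from compound 2 to compound 3 (0.30 log units; that floor lies within the scatter). The estimate for compound 3 is 50000 nM, with an expected range from 10000 nM to 100000 nM.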

Compound 3, half-maximal cytotoxic concentration: 9400 nM
Estimate against measurement, compound 3: 5.3-fold (0.73 log units) above; the measured number lies below the stated range.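

In this assay, 3-fluorophenyl on the amide-type nitrogen in place of 3-(methylsulfanyl)propyl gives an at least 10-fold lower number from compound 2 to compound 3 (1.02 log units; beyond the scatter), and the same group in place of ethyl gives an at least 10-fold lower number from compound 1 to compound 3 (1.02 log units; beyond the scatter). Among the compounds shown here, the group on this nitrogen therefore does change the read-out, which the two chain compounds could not show, as the step between them cannot be read; compound 3 is the first compound here with an exact number, and it stands for higher toxicity in this test than either chain compound. Both new steps are minimum sizes, and the full size of the change stays hidden at the upper end of the scale: the limit of > 100000 nM in this assay, at which 2 of the 3 values shown sit.

As far as these compounds go, whether the change follows the aromatic ring as such or its fluorine stays open, and a plain phenyl or a cyclohexyl group on the same nitrogen would separate the two. Also open is whether the lower number goes with rings on this nitrogen in general, as compound 3 is the only compound shown with a ring there.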